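A few compounds are considered here, and "the series" means these few. Any claim that something is new, unique, unknown or untested is made for them only; others in the source may bear on it.

Working notes on the series. In a functional assay on L1210 cells (Mus musculus) for antiproliferative activity (a lower number here means a stronger inhibitor, a higher number a weaker inhibitor), compound 1 `COc1cc2c(c(O)c1OC)c(=O)ccn2C` gives > 40000 nM as a limit, not a number. Compound 2 `COc1cc2c(c(OC)c1OC)c(=O)ccn2C` gives > 40000 nM in this assay, again only a limit. Both measured compounds therefore sit at the limit of > 40000 nM in this assay, at which 2 of the 2 values shown sit, and neither has a true position in the assay.

The next structure is compound 3 `COc1cc2c(=O)ccn(C)c2cc1OC`, reached by hydrogen in place of methoxy on an aromatic carbon with hydrogen in place of methoxy on an aromatic carbon. Within the data shown here, the only measured step, a step that the two limits leave unreadable from compound 1 to compound 2, changes a different group and gives no size to carry over. Nothing measured points to a gain in this assay, so no step beyond the scatter is expected in either direction. The expected change, a number no higher from compound 2 to compound 3 (the limit leaves the size open), is an estimate that rests on this lack of any readable step. For compound 3 the estimated value is 40000 nM with an expected range of 15000 nM to 80000 nM in this estimate, and a report as a limit is the likeliest outcome.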

Compound 3, half-maximal inhibitory concentration: > 40000 nM
Compound 3 ended at the assay's limit; the forecaster's own chance of this, stated with the estimate: 85%; the middle value sits exactly at the limit.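

Compound 3 gives > 40000 nM in this assay, a limit and not a number. No step among compound 1, compound 2 and compound 3 can be read, as all three stand at the same place: the limit of > 40000 nM in this assay, at which 3 of the 3 values shown sit.

The compounds shown leave open which change to the shared core, if any, would give a true value in this assay.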